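This account rests on a few compounds, and the source may have more. Where it says the series, first, only, none or still open, it means among the compounds named here.

Compound 1 `CNC(=O)c1cc(Oc2ccc(C(=O)/C=C/c3cccc([N+](=O)[O-])c3)cc2)ccn1`, compound 2 `CNC(=O)c1cc(Oc2ccc(C(=O)/C=C/c3ccc(C#N)cc3)cc2)ccn1` and compound 3 `CNC(=O)c1cc(Oc2ccc(C(=O)/C=C/c3ccco3)cc2)ccn1` share one core, joined through a double-bonded chain to a changing aromatic group. In a functional assay on PC-3 cells (Homo sapiens) for cytotoxicity, read by MTT assay, with a stated time of 72 h (on this read-out higher numbers stand for weaker inhibition and lower numbers for stronger inhibition), compound 2 gives 3870 nM. Compound 1 gives "not determined" (no result reported) in this assay. Compound 3 stands without a number: in this assay compound 3 gives "not determined" (no result reported), so nothing places it against compound 2. Compound 4 `CNC(=O)c1cc(Oc2ccc(C(=O)/C=C/c3ccc(OC)cc3)cc2)ccn1` differs from compound 3 by 4-methoxyphenyl in place of furan-2-yl on a double-bonded chain carbon bound to a double-bonded chain carbon. Among the compounds with values here, no step between measured compounds is known here, and no value for compound 3 anchors the change, so the only footing is the single number of compound 2. Compound 4 is therefore expected to land near that number, at an estimated 5000 nM with a range from 1500 nM to 20000 nM.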

Compound 4, half-maximal inhibitory concentration: > 50000 nM
Compound 4: a limit, no number (the forecaster's own chance of this, stated with the estimate: 25%); middle value at least 10-fold (1.00 log units) from the limit.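

Methoxy in place of cyano on an aromatic carbon gives an at least 12-fold higher number from compound 2 to compound 4 (1.11 log units; beyond the scatter), the first change in this series that can be read in this assay, and it shows that the group at this place matters. For compound 4 the result is a limit of the assay and not a number: the limit of > 50000 nM in this assay, at which 1 of the 4 values shown sits.

The step from compound 3 to compound 4 cannot be read, as compound 3 has no number. On these data alone, it remains open where an amine or a fluorine on that aromatic carbon would fall.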